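Methyl to Methoxy on a Shared Aryl Group

The compounds below may be only part of what the source reports. "The series", "measured", "known", "first", "only" and "open" are said of these compounds alone.

Compound 1 `COc1ccc(-c2cc(NC(=S)NNC(=O)c3ccc(C)cc3)cs2)cc1`: 30000 nM
Compound 2 `Cc1ccc(C(=O)NNC(=S)Nc2csc(-c3ccc(C)cc3)c2)cc1`: 40000 nM
Compound 3 `Cc1ccc(-c2nnc(Nc3csc(-c4ccccc4)c3)s2)cc1`: "not determined" (no result reported)

Two measured compounds set the frame. In a functional assay on Hs 683 cells (Homo sapiens) for inhibition, read by colorimetric assay and MTT assay, with a stated time of 72 h (on this read-out lower numbers stand for stronger inhibition and higher numbers for weaker inhibition), compound 2 gives 40000 nM, and compound 1 gives 30000 nM. The two differ in one place only, (methoxy in place of methyl on an aromatic carbon), and the step of a 1.3-fold lower number from compound 2 to compound 1 (0.12 log units; within the scatter), so the two numbers cannot be told apart by this read-out.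

Compound 3 `Cc1ccc(-c2nnc(Nc3csc(-c4ccccc4)c3)s2)cc1` carries a different core from compound 2; the difference between the two cores is not broken down here. For compound 3 this assay gives "not determined" (no result reported), so there is no number to set beside the others.

Compound 4 `COc1ccc(-c2nnc(Nc3csc(-c4ccccc4)c3)s2)cc1` stands to compound 3 as compound 1 stands to compound 2: the change is methoxy in place of methyl on an aromatic carbon, and the place and the group are the same in both pairs. In this assay, going by the values given here, the one measured pair shows a 1.3-fold lower number from compound 2 to compound 1 (0.12 log units; within the scatter), a step that stays within the scatter; a step of about that size is therefore expected from compound 3 to compound 4, and this rests on that one measured pair alone. Since compound 3 itself has no number, the level of compound 4 can only be set loosely, using the levels of compound 1 at 30000 nM and compound 2 at 40000 nM as the nearest guide. Compound 4 is estimated at 25000 nM in this assay, expected to fall between 4000 nM and 100000 nM.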

Compound 4, half-maximal inhibitory concentration: 5000 nM
Estimate against measurement, compound 4: 5.0-fold (0.70 log units) above; low and high end bracket the measured number.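

In this assay, going by these compounds alone, compound 3 has no number to pair with compound 4 at 5000 nM, so no step between the two can be read. The compounds shown leave open whether 4-methylphenyl to 4-methoxyphenyl acts on the core of compound 3 as it does on the core of compound 2. Nothing shown here offers an explanation for the level of compound 4.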